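The source may hold more compounds than are shown below. What is called first, only, known or untested is meant among the compounds shown, and "the series" means these compounds.

The measured compounds:

Compound 1, `CNC(=O)c1cc(C(=O)NC2CC2)cn(CC2CCCOC2)c1=O`. In a physicochemical assay for solubility (on this read-out higher numbers stand for higher solubility and lower numbers for lower solubility), compound 1 gives >= 131 ug/mL, which is a limit of the assay rather than a number.
Compound 2, `CNC(=O)c1cc(C(=O)NCCOC)cn(Cc2ccccc2)c1=O`. In this assay compound 2 gives >= 164 ug/mL, likewise a limit.
Compound 3, `CNC(=O)c1cc(C(=O)NCCC(C)C)cn(Cc2ccccc2)c1=O`. In this assay compound 3 gives 10 ug/mL.

Compound 1 thus stands only at a limit; two of the three values shown are limits (the limit of >= 131 ug/mL in this assay, at which 1 of the 3 values shown sits, (the limit of >= 164 ug/mL in this assay, at which 1 of the 3 values shown sits)), and only compound 3 yields a number. The unmeasured compound 4, `CNC(=O)c1cc(C(=O)NC2CC2)cn(Cc2cccc(C)c2)c1=O`, differs from compound 1 in a single place: 3-methylphenyl in place of oxan-3-yl on a saturated chain carbon bound to an aromatic nitrogen. For the measured compounds named here, no measured step touches this position. Going by the values given here, the one measured step, an at least 16-fold lower number from compound 2 to compound 3 (1.21 log units; beyond the scatter), sits on the amide-side chain, where methoxy gave way to isopropyl, and it was large and downward. Going by these compounds, the change from compound 1 to compound 4 also exchanges a saturated ring holding one oxygen for an all-carbon aromatic ring, so by analogy a downward step in this assay is expected, though it is unknown how far compound 1 itself lies above its limit. Compound 4 is therefore estimated at 30 ug/mL, within 8 ug/mL to 120 ug/mL. The expected step for compound 4 is an at least 4.3-fold lower number from compound 1 to compound 4 (0.64 log units; beyond the scatter).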

Compound 4, solubility: >= 205 ug/mL
Compound 4 ended at the assay's limit; the forecaster's own chance of this, stated with the estimate: 15%; at least 6.8-fold (0.83 log units) between middle value and limit.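

The step between compound 1 and compound 4 cannot be read: in this assay both values are limits, not numbers. The compounds shown leave open whether 3-methylphenyl in place of oxan-3-yl on a saturated chain carbon bound to an aromatic nitrogen shifts this read-out at all, and in which direction.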